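Hydroxy on the saturated ring carbon of compound 1

The source may report more compounds than this note shows. Statements on the series, on what has been measured and on what is new or still open speak of the compounds shown alone.

In a functional assay on NCI-H460 cells (Homo sapiens) for antiproliferative activity, read by MTT assay, with a stated time of 48 h (on this read-out higher numbers stand for weaker inhibition and lower numbers for stronger inhibition), compound 1 (`Cc1ccc(Nc2ccc3c(c2)C(CCC(C)C)C(=O)N3)cc1`) gives 55300 nM and compound 2 (`CC(C)CCC1C(=O)Nc2ccc(Nc3ccc(Cl)cc3)cc21`) gives 48700 nM. For the measured compounds named here, these are the only two numbers so far and they lie within the scatter of each other, so compound 1 has no separate standing on this scale. Going by the values given here, the single measured step is a 1.1-fold lower number from compound 1 to compound 2 (0.06 log units; within the scatter), for chloro in place of methyl on an aromatic carbon.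

Compound 3 (`Cc1ccc(Nc2ccc3c(c2)C(O)(CCC(C)C)C(=O)N3)cc1`) differs from compound 1 elsewhere: hydroxy in place of hydrogen on a saturated ring carbon, (hydroxy in place of hydrogen on a saturated ring carbon). Among the compounds with values here, no measured step involves that carbon, so the data give no direction for this change. The step to compound 2 bears on it only loosely, showing that one change on the core of compound 1 left compound 2 at 48700 nM. No shift beyond the scatter is therefore expected in this assay, though the range must stay wide. The expected change is a 1.2-fold lower number from compound 1 to compound 3 (0.09 log units; within the scatter). The estimate for compound 3 is 45000 nM, with an expected range of 15000 nM to 120000 nM.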

Compound 3, half-maximal inhibitory concentration: 22700 nM
For compound 3 the middle estimate is 2.0-fold (0.30 log units) above the measured one, within the range that was stated.
By their numbers in this assay, from the lowest: compound 3; then compounds 2 and 1 (each within the scatter of the next).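

In this assay, for the compounds shown here, the hydroxy in place of hydrogen on a saturated ring carbon gives the first step that lies beyond the scatter (a 2.4-fold lower number from compound 1 to compound 3 (0.39 log units; beyond the scatter)), though it is a modest one. The only earlier step, chloro in place of methyl on an aromatic carbon, stayed within the scatter (a 1.1-fold lower number from compound 1 to compound 2 (0.06 log units; within the scatter)), so this saturated ring carbon, two ring bonds from the ring nitrogen, is the one place on the core of compound 1 shown so far where a change of a single heavy atom moves the number beyond the scatter, and the direction is towards stronger inhibition. Nothing measured alongside these numbers accounts for the shift, which rests on this one pair of compounds.

Going by these compounds, whether the step belongs to hydroxy itself stays open, and a methoxy, an amine or a fluoro on the same saturated ring carbon would bear on that question. Also open, on these data alone, is whether hydroxy at this carbon gives a step of similar size on compound 2, with chloro in place of methyl, or only on the core of compound 1.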